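Piperidine esters: effect of the ring nitrogen substituent

The compounds below may be only part of what the source reports. "The series", "measured", "known", "first", "only" and "open" are said of these compounds alone.

Measured compounds:
compound 1 `[N-]=[N+]=NCCCN1CCCC(COC(=O)c2ccccc2-c2ccccc2)C1` — 4270 nM
compound 2 `O=C(OCC1CCCN(CCCc2ccccc2)C1)c1ccccc1-c1ccccc1` — 13500 nM; 13500 nM (2 entries)

Within the data shown here, in an in vitro functional assay on HEK ts201 cells for antagonist activity at Neuronal acetylcholine receptor; alpha4/beta2 (Homo sapiens), read by fluorescence and calcium flux (on this read-out higher numbers stand for weaker inhibition and lower numbers for stronger inhibition), compound 1 gives 4270 nM, the only single number for it; a further entry for compound 1 carries no single number. Compound 2 gives in this assay 13500 nM; 13500 nM (2 entries), recorded twice at the same value. Among the measured compounds shown here, the two compounds differ at the ring nitrogen, but no step between them has been worked out, so only the two values themselves stand side by side.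

Compound 3 `O=C(OCC1CCCNC1)c1ccccc1-c1ccccc1` is not yet measured. It differs from compound 1 by hydrogen in place of 3-azidopropyl on an amine nitrogen in a ring. For the measured compounds named here, no measured pair shows the size of such a step, so the direction is open. Starting from compound 1 at 4270 nM, compound 3 is expected to come out at 8000 nM, between 2000 nM and 32000 nM. The expected step of a 1.9-fold higher number from compound 1 to compound 3 (0.27 log units; within the scatter) is a modest loss, not clearly beyond the scatter.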

Compound 3, half-maximal inhibitory concentration: 7080 nM
Estimate against measurement, compound 3: 1.1-fold (0.05 log units) above; low and high end bracket the measured number.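

In this assay, hydrogen in place of 3-azidopropyl on the amine nitrogen in the ring gives a 1.7-fold higher number from compound 1 to compound 3 (0.22 log units; within the scatter). Among these compounds, this is the only measured step at this position, and it shows that removing the whole 3-azidopropyl group leaves the read-out within the usual scatter, so on this pair the group is not needed to keep the inhibition seen with compound 1. Nothing on hand explains this outcome.

Open, as far as these compounds go, is how the same nitrogen reads with other substituents, such as a methyl group, a longer chain, or a chain ending in an amine or a carboxylic acid. Also open, from the compounds shown here alone, is how an amide in place of the ester would read in this assay.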